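Ring size at the thiocarbonyl: piperidine versus pyrrolidine

The compounds below may be only part of what the source reports. "The series", "measured", "known", "first", "only" and "open" are said of these compounds alone.

Compound 1 `N/C(=N\NC(=S)N1CCCCC1)c1ccccn1` gives 79.7% in a functional assay on A-431 cells (Homo sapiens) for cytotoxicity, read by MTT assay, with a stated time of 72 h, tested at 30 uM; on this read-out lower numbers stand for less inhibition of growth and higher numbers for more inhibition of growth at the one concentration tested. Compound 2 `N/C(=N\NC(=S)N1CCCC1)c1ccccn1` carries the change pyrrolidin-1-yl in place of piperidin-1-yl on a thiocarbonyl carbon and gives 85.2% in this assay; the step of a number 5.5 percentage points higher from compound 1 to compound 2 (within the scatter) is small. Going by the values given here, compound 3 `Cc1ccnc(/C(N)=N/NC(=S)N2CCCCC2)c1` differs from compound 1 by methyl in place of hydrogen on an aromatic carbon; in this assay compound 3 gives 62.8%, the lowest of the three numbers; the step of a number 16.9 percentage points lower from compound 1 to compound 3 (beyond the scatter) is the only one among the measured pairs that lies beyond the scatter.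

Compound 4 `Cc1ccnc(/C(N)=N/NC(=S)N2CCCC2)c1` has not been measured. Among the compounds with values here, it relates to compound 3 as compound 2 relates to compound 1: the change pyrrolidin-1-yl in place of piperidin-1-yl on a thiocarbonyl carbon is the same change as the one from compound 1 to compound 2, made on the core of compound 3 rather than on the core of compound 1, the two cores differing by methyl in place of hydrogen on an aromatic carbon. Within the data shown here, the one earlier instance of this change gave a number 5.5 percentage points higher from compound 1 to compound 2 (within the scatter), a step within the scatter, so no real shift is known for it. Among the measured compounds shown here, on that single precedent the step from compound 3 to compound 4 is expected to be of the same small size, a number 5.2 percentage points higher from compound 3 to compound 4 (within the scatter), with the width of the range reflecting that only one example supports it. Compound 4 is therefore estimated to give 68% in this assay, expected to lie between 55% and 81%.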

Compound 4, percent growth inhibition at one concentration: 84.2%
Estimate against measurement, compound 4: 16.2 percentage points below, outside the stated range (above it).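

In this assay, pyrrolidin-1-yl in place of piperidin-1-yl on a thiocarbonyl carbon does not carry over from one core to the other at a constant size, the new result being a number 21.4 percentage points higher from compound 3 to compound 4 (beyond the scatter), and the two steps differ: the same change on two cores in this assay, a number 5.5 percentage points higher (within the scatter) from compound 1 to compound 2 and a number 21.4 percentage points higher (beyond the scatter) from compound 3 to compound 4, 15.9 percentage points apart, beyond the scatter of two such steps

Seen from the other side of the same set of compounds, methyl in place of hydrogen on an aromatic carbon depends on the group on the thiocarbonyl carbon, the new result being a number 1 percentage points lower from compound 2 to compound 4 (within the scatter), and again the two steps differ: the same change on two cores in this assay, a number 16.9 percentage points lower (beyond the scatter) from compound 1 to compound 3 and a number 1 percentage points lower (within the scatter) from compound 2 to compound 4, 15.9 percentage points apart, beyond the scatter of two such steps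

These two comparisons are one observation on a single set of four compounds, read at one concentration in one cell line, so they show that the two changes are not additive here but give neither a cause nor a rule for other compounds.

Still open, as far as these compounds go, is whether this dependence on the core extends to a morpholin-4-yl or azepan-1-yl group on the thiocarbonyl carbon. Also open, from the compounds shown here alone, is how a methoxy group or a chlorine atom in place of the methyl would behave with each of the two rings.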